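The source may report more compounds than this note shows. Statements on the series, on what has been measured and on what is new or still open speak of the compounds shown alone.

Measured so far:
compound 1 `C=CCN(CC=C)C(=S)N/N=C\c1ccc([N+](=O)[O-])cc1` — < 206000 nM in an ADME assay on Vero cells (Chlorocebus sabaeus) for cytotoxicity, read by MTT assay, with a stated time of 72 h; on this read-out higher numbers stand for lower toxicity in this test and lower numbers for higher toxicity in this test
compound 2 `Cc1ccccc1/C=N\NC(=S)N(Cc1ccccc1)Cc1ccccc1` — 167000 nM in this assay
compound 3 `C=CCN(CC=C)C(=S)N/N=C(/C)c1ccc(F)cc1` — 214000 nM in this assay

All three compounds share a thiosemicarbazone core and were tested in this assay. For compound 1 the result is not a number but a limit of the test, (the limit of < 206000 nM in this assay, at which 1 of the 3 values shown sits). Compound 2 and compound 3 give numbers that sit close to one another, and a gap of that size between them is within the usual scatter of repeated measurements, so neither can be called the more or the less toxic of the two.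

The compound not yet measured is compound 4 `C=CCN(CC=C)C(=S)N/N=C\c1ccc(Cl)cc1`. It differs from compound 1 in one place: chloro in place of nitro on an aromatic carbon. The core, the two allyl groups on the nitrogen and the rest of the aromatic ring are kept.

Among the compounds shown, no pair differs in one place only, so there is no measured step to lean on. The values that do exist all lie in one narrow band, and nothing in them points to a large shift in either direction for this change. The step from compound 1 to compound 4 is therefore expected to be small, a step that the limit leaves unreadable from compound 1 to compound 4, and is expected to stay within the scatter of the test.

For compound 4 the expected value in this assay is 190000 nM, with a likely range from 100000 nM to 350000 nM.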

Compound 4, half-maximal cytotoxic concentration: 213000 nM
For compound 4 the middle estimate is 1.1-fold (0.05 log units) below the measured one; measured number inside the range.
By their numbers in this assay, from the lowest: compounds 2, 4 and 3 (each within the scatter of the next).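

In this assay, compound 4 shows that this place, an aromatic carbon para to a large group, can hold chloro and give a true number, which compound 1 with its nitro does not provide. Among these compounds, this gives the first measured step at this place, though only as a floor: an at least 1.0-fold higher number from compound 1 to compound 4 (0.01 log units; that floor lies within the scatter). The result for compound 1 is a limit of the test, not a number, so the full size of the change from nitro to chloro, and even whether it is a real change at all, cannot be read: the limit of < 206000 nM in this assay, at which 1 of the 4 values shown sits.

What the compounds shown leave open is how other groups behave at this same aromatic carbon, for example an amine or a carboxylic acid, and whether either would give a number far from that of compound 4. Among the compounds shown here, they also leave open whether chloro at this place would give a similar result if the two allyl groups on the nitrogen were replaced by a longer chain, since no pair here tests that change in one place only.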